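Changing the Halogen on the Aryl Ring of Compound 1

This account rests on a few compounds, and the source may have more. Where it says the series, first, only, none or still open, it means among the compounds named here.

Within the data shown here, compound 1 `COc1cc(OC)c(C(=O)/C=C/c2cccc(Cl)c2)c(O)c1CC=C(C)C` is the only member of this set with a read number: in an ADME assay on MCF7-DOX cells (Homo sapiens) for cytotoxicity, read by MTT assay, with a stated time of 48 h (on this read-out higher numbers stand for weaker inhibition and lower numbers for stronger inhibition), compound 1 gives 59500 nM. Compound 2 `CCCCCc1c(OC)cc(OC)c(C(=O)/C=C/c2cccc(N3CCNCC3)c2)c1O` reaches only a limit of the assay, giving > 100000 nM. Compound 3 `CCCCc1c(OC)cc(OC)c(C(=O)/C=C/c2cccc(N3CCNCC3)c2)c1O` likewise stops at a limit, giving > 100000 nM. The step that the two limits leave unreadable from compound 2 to compound 3 therefore cannot be sized, and the limit of > 100000 nM in this assay, at which 2 of the 3 values shown sit, is all these two compounds show. Compound 4 `COc1cc(OC)c(C(=O)/C=C/c2ccc(F)cc2)c(O)c1CC=C(C)C` differs from compound 1 by 4-fluorophenyl in place of 3-chlorophenyl on a double-bonded chain carbon bound to a double-bonded chain carbon. Among the measured compounds shown here, no measured step touches this part of the structure, so nothing here argues for a change beyond the usual scatter, and compound 4 is expected to sit near compound 1. The estimate for compound 4 is 60000 nM, within 25000 nM to 140000 nM. The step of a 1.0-fold higher number from compound 1 to compound 4 (0.00 log units; within the scatter) is thus expected to stay inside the scatter.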

Compound 4, half-maximal inhibitory concentration: 53700 nM
Estimate against measurement, compound 4: 1.1-fold (0.05 log units) above, within the range that was stated.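

In this assay, among these compounds, replacing 3-chlorophenyl with 4-fluorophenyl on the double-bonded chain carbon gives a 1.1-fold lower number from compound 1 to compound 4 (0.04 log units; within the scatter), the first readable step at this position, and it shows that this exchange moves the read-out no further than the scatter. The halogen and its place on the ring changed together here, so this one step does not separate the two. No measurement shown offers a reason for this result. Still open, on these data alone, is how a nitrile or a carboxylic acid on this ring would read.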